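A few compounds are considered here, and "the series" means these few. Any claim that something is new, unique, unknown or untested is made for them only; others in the source may bear on it.

Measured so far in a functional assay on HO8910 cells (Homo sapiens) for inhibition, read by MTT assay, with a stated time of 24 h, tested at 10 ug/mL; on this read-out higher numbers stand for more inhibition of growth at the one concentration tested and lower numbers for less inhibition of growth:
Compound 1 `O=C(CCCCC(S)CCS)NO`: 26.2%
Compound 2 `O=C(CCCCC(S)CCS)Nc1ccccc1`: 5.49%
Compound 3 `O=C(CCCCC(S)CCS)Nc1ccccc1Cl`: "not active" (no number reported)

Of the two compounds with a number, compound 2 stands lower, with 5.49% against 26.2% for compound 1. Compound 4 `O=C(CCCCC(S)CCS)Nc1cccc(Cl)c1` is the next to be tested. It differs from compound 2 by chloro in place of hydrogen on an aromatic carbon.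

Among the compounds with values here, only one measured step has a size: a number 20.7 percentage points lower from compound 1 to compound 2 (beyond the scatter). That change lies on the amide-type nitrogen, not on the ring, so it says little about a new chloro. The closest comparison is compound 3, which also carries a chloro, at another place on the ring. Compound 3 is reported as "not active" (no number reported), so it gives no step size, though it offers no sign of a gain. In this assay, no step beyond the scatter is therefore expected. The estimated change is a number 0.5 percentage points higher from compound 2 to compound 4 (within the scatter). For compound 4 the expected value is 6%, with an estimated range from 0% to 18%.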

Compound 4, percent growth inhibition at one concentration: "not active" (no number reported)
Compound 4: no number reported, and the estimate cannot be compared.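

Within the data shown here, compound 4, like compound 3, is reported in this assay as "not active" without a number, so no step from compound 2 to either can be read. No available evidence explains this result. From the compounds shown here alone, whether a chloro on the ring changes growth inhibition at all remains open.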